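From compound 1 to compound 4: one added group

This account rests on a few compounds, and the source may have more. Where it says the series, first, only, none or still open, it means among the compounds named here.

Compound 1 `O=c1cc(N2CCNCC2)nc2sc(-c3ccccc3)nn12` (3000 nM)
Compound 2 `CC(C)(C)c1nn2c(=O)cc(N3CCNCC3)nc2s1` (4000 nM)
Compound 3 `O=C(O)c1ccc(-c2nn3c(=O)cc(N4CCNCC4)nc3s2)cc1` (6500 nM)

In a functional assay on cells (Platelet) for inhibition (a higher number here means a weaker inhibitor, a lower number a stronger inhibitor), compound 1 sits at the low end of these three, at 3000 nM and with no clear gap to compound 2. Putting tert-butyl in place of phenyl gives a 1.3-fold higher number from compound 1 to compound 2 (0.12 log units; within the scatter) and so changes little. Putting carboxy in place of hydrogen on an aromatic carbon gives a 2.2-fold higher number from compound 1 to compound 3 (0.34 log units; beyond the scatter) and is a modest rise.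

Compound 4 `C[C@H](N)C(=O)Nc1cccc(-c2nn3c(=O)cc(N4CCNCC4)nc3s2)c1` differs from compound 1 in one place. The change is ((1-aminoethyl)carbonyl)amino in place of hydrogen on an aromatic carbon and it puts ((1-aminoethyl)carbonyl)amino in place of hydrogen on an aromatic carbon of a six-membered aromatic ring of carbon only, meta to a large group.

Among the compounds with values here, no measured compound carries this group, so the two steps offer only a rough size. Compound 3 is the nearest guide, since it also replaces a hydrogen on an aromatic carbon, and its step is a 2.2-fold higher number from compound 1 to compound 3 (0.34 log units; beyond the scatter) in size. A small step in this assay is therefore expected, slightly upward if any. The expected size is a 1.2-fold higher number from compound 1 to compound 4 (0.07 log units; within the scatter) and no clear shift is foreseen. Compound 4 is estimated at 3500 nM with an expected range of 1000 nM to 12000 nM in this measurement.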

Compound 4, half-maximal inhibitory concentration: 5870 nM
Beside the measured number, compound 4's estimate is 1.7-fold (0.22 log units) below it; the range from low to high includes it.
By their numbers in this assay, from the lowest: compounds 1, 2, 4 and 3 (each within the scatter of the next, the first and the last beyond it).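

In this assay, placing ((1-aminoethyl)carbonyl)amino on an aromatic carbon of the six-membered ring, meta to a large group, gives a 2.0-fold higher number from compound 1 to compound 4 (0.29 log units; within the scatter), so this group of 6 heavy atoms, with its 2 hydrogen-bond donors and its defined stereocentre, brings no clear change. Before this result, the only addition to this ring was carboxy, with a 2.2-fold higher number from compound 1 to compound 3 (0.34 log units; beyond the scatter), and the new group is a second addition that gives no clearly lower number, which suggests that the ring can carry a sizeable group without a clear loss in this assay. Nothing measured here accounts for this result.

Going by these compounds, whether a plain amine in the same place would also leave the number unchanged remains open, as does whether the opposite form of the stereocentre would give a different number. Also open, on these data alone, is whether any addition to this ring can bring the number clearly below that of compound 1, at 3000 nM.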